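The source may hold more compounds than are shown below. What is called first, only, known or untested is meant among the compounds shown, and "the series" means these compounds.

Compound 1 `Cc1cc(S(N)(=O)=O)ccc1NC(=O)COc1ccc(Cl)cc1Oc1ccc2ccccc2c1` and compound 2 `Cc1cc(S(N)(=O)=O)ccc1NC(=O)COc1ccc(F)cc1Oc1ccc2cc(Br)ccc2c1` share a common core. In an ADME assay on C8166 cells (Homo sapiens) for cytotoxicity, read by MTT assay (on this read-out lower numbers stand for higher toxicity in this test and higher numbers for lower toxicity in this test), compound 1 gives 119000 nM. For compound 2, this assay reports only a limit, > 357000 nM, so compound 2 stands at the edge of what the assay resolves, as noted by the limit of > 357000 nM in this assay, at which 1 of the 2 values shown sits. Compound 3 `Cc1cc(S(N)(=O)=O)ccc1NC(=O)COc1ccc(F)cc1Oc1ccc2cc(Br)ccc2c1Cl` differs from compound 2 by chloro in place of hydrogen on an aromatic carbon, a chloro in place of hydrogen on an aromatic carbon. Going by the values given here, no step between measured compounds is available to set the size of such a change, and no measured property of the chloro group is given. Compound 3 is therefore expected to remain close to where compound 2 stands, with an expected step of an at least 1.1-fold lower number from compound 2 to compound 3 (0.07 log units; that floor lies within the scatter) in this assay that does not exceed the usual scatter. The estimate for compound 3 in this assay is 300000 nM, with a range from 100000 nM to 600000 nM, and a further limit-only reading is considered the most likely outcome.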

Compound 3, half-maximal cytotoxic concentration: 195000 nM
The estimate for compound 3 lay 1.5-fold (0.19 log units) above the measured number, and the stated range covers the measured number.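

The chloro group on this aromatic carbon, ortho to a fused ring, gives compound 3 a measured number in this assay, which the 6-bromonaphthalen-2-yl group of compound 2 did not yield. The change reads as an at least 1.8-fold lower number from compound 2 to compound 3 (0.26 log units; that floor lies within the scatter), so the direction rests on a floor that does not clear the usual scatter. The true size of the step cannot be told, because compound 2 is held at a limit: the limit of > 357000 nM in this assay, at which 1 of the 3 values shown sits.

The compounds shown leave open how a methyl, a methoxy or an amine on this same carbon would read in this assay. They also leave open whether chloro at this place would give a similar step on a naphthalene without the bromo group.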